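This account rests on a few compounds, and the source may have more. Where it says the series, first, only, none or still open, it means among the compounds named here.

Measured compounds: compound 1, `Cc1cc(C)c(S(=O)(=O)NCCN2CCC(C)CC2)c(C)c1`; compound 2, `CC1CCN(C2CCN(S(=O)(=O)c3cccc(-c4ccccc4F)c3)CC2)CC1`; compound 3, `CC1CCN(C2CCN(S(=O)(=O)c3ccccc3-c3ccccc3)CC2)CC1`.

In an ADME assay on HCT-116 cells (Homo sapiens) for cytotoxicity, read by CellTiter-Glo, with a stated time of 72 h (a higher number here means a weaker inhibitor, a lower number a stronger inhibitor), compound 1 gives > 5000 nM, which is a limit of the assay rather than a number. Compound 2 gives > 5000 nM in this assay, again a limit. Compound 3 gives > 5000 nM, likewise a limit. Compound 2 therefore stands at the limit of > 5000 nM in this assay, at which 3 of the 3 values shown sit, with no number of its own to compare. Compound 4, `CC1CCN(C2CCN(S(=O)(=O)c3cccc(Br)c3)CC2)CC1`, has not yet been measured; it differs from compound 2 as follows: bromo in place of 2-fluorophenyl on an aromatic carbon. Within the data shown here, no step between measured compounds is available, so the expectation rests on the three limits alone. The step is expected to be none beyond the scatter, a step that the limit leaves unreadable from compound 2 to compound 4. Compound 4 is estimated at 10000 nM, in the range 5000 nM to 40000 nM.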

Compound 4, half-maximal inhibitory concentration: > 5000 nM
Compound 4: only a limit was reported; the forecaster's own chance of this, stated with the estimate: 85%; the middle value does not contradict the limit.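

In this assay, among these compounds, compound 2 and compound 4 both give only limits, so no step between them can be read: the limit of > 5000 nM in this assay, at which 4 of the 4 values shown sit. As far as these compounds go, whether bromo and 2-fluorophenyl differ at all in this assay stays open.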